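The source may hold more compounds than are shown below. What is called first, only, known or untested is meant among the compounds shown, and "the series" means these compounds.

The study places three measured compounds beside one not yet tested. Compound 1 `Cc1nnc(SCc2cc(=O)c3ccccc3o2)s1` was run in a functional assay on HEp-2 cells (Homo sapiens) for cytotoxicity, read by MTT assay, with a stated time of 72 h (a lower number here means a stronger inhibitor, a higher number a weaker inhibitor), where compound 1 gives only a limit, > 25000 nM. Compound 2 `Cc1cc(C)nc(SCc2cc(=O)c3ccccc3o2)n1` in this assay also gives a limit, > 25000 nM. Compound 3 `Cc1ccc2oc(CSc3nc(C)cc(C)n3)cc(=O)c2c1` gives a limit as well in this assay, > 25000 nM. Compound 3 arises from compound 2 by methyl in place of hydrogen on an aromatic carbon; the resulting step that the two limits leave unreadable from compound 2 to compound 3 cannot be sized because of the limit of > 25000 nM in this assay, at which 3 of the 3 values shown sit. How the core of compound 1 differs from the core of compound 2 is not broken down here.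

Compound 4 `Cc1ccc2oc(CSc3nnc(C)s3)cc(=O)c2c1`, still unmeasured, carries the same change relative to compound 1: methyl in place of hydrogen on an aromatic carbon. Since the two place descriptions agree word for word, this is the same change, not merely the same kind. Because compound 1 already sits at > 25000 nM and the measured pair sits at the limit of > 25000 nM in this assay, at which 3 of the 3 values shown sit, the change gives no reason to expect movement. The step that the limit leaves unreadable from compound 1 to compound 4 is therefore estimated to be small. Compound 4 is expected to show 40000 nM, within 20000 nM to 100000 nM in this assay.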

Compound 4, half-maximal inhibitory concentration: > 25000 nM
Compound 4: only a limit was reported; the forecaster's own chance of this, stated with the estimate: 85%; the middle value is on the limit's open side.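

No step from compound 1 to compound 4 can be read, because compound 1 and compound 4 each give only a limit, not a number: the limit of > 25000 nM in this assay, at which 4 of the 4 values shown sit.

The compounds shown leave open how strong any of the four is, and whether methyl in place of hydrogen on an aromatic carbon changes the result at all.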